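Aryl swap in the bis(trifluoromethyl)benzenesulfonamide diamine series

The source may report more compounds than this note shows. Statements on the series, on what has been measured and on what is new or still open speak of the compounds shown alone.

Compound 3 `O=S(=O)(NCCCNCc1ccc(Cl)c(Cl)c1)c1cc(C(F)(F)F)cc(C(F)(F)F)c1` gives 1500 nM in a functional assay on A2780 cells (Homo sapiens) for inhibition, read by MTT assay, with a stated time of 72 h; a lower number here means a stronger inhibitor of growth, a higher number a weaker inhibitor of growth. Compound 2 `O=S(=O)(NCCCCNCc1ccc(Br)cc1)c1cc(C(F)(F)F)cc(C(F)(F)F)c1` gives 2100 nM, and the step of a 1.4-fold lower number from compound 2 to compound 3 (0.15 log units; within the scatter) changes the chain length together with the aryl group. Within the data shown here, compound 1 `O=S(=O)(NCCNCc1cccc2ccccc12)c1cc(C(F)(F)F)cc(C(F)(F)F)c1` gives 21000 nM, a gap from compound 3 beyond the scatter; no single-point step links these two, so only the values are set side by side. Compound 4 `O=S(=O)(NCCCNCc1ccc(C(F)(F)F)cc1)c1cc(C(F)(F)F)cc(C(F)(F)F)c1` differs from compound 3 by 4-(trifluoromethyl)phenyl in place of 3,4-dichlorophenyl on a saturated chain carbon bound to an amine nitrogen. Among the measured compounds shown here, no measured step changes the aryl substitution pattern alone, and the one step that touches it stays within the scatter. Compound 4 is therefore expected at 2500 nM, within 900 nM to 7000 nM, a step of a 1.7-fold higher number from compound 3 to compound 4 (0.22 log units; within the scatter) not expected to exceed the scatter.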

Compound 4, concentration for 50% growth inhibition: 2800 nM
For compound 4 the middle estimate is 1.1-fold (0.05 log units) below the measured one, and the stated range covers the measured number.
By their numbers in this assay, from the lowest: compounds 3, 2 and 4 (each within the scatter of the next); then compound 1.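

Among these compounds, the step of a 1.9-fold higher number from compound 3 to compound 4 (0.27 log units; within the scatter) in this assay is the first to change the aryl group alone, with the chain unchanged, on a saturated chain carbon bound to an amine nitrogen. Exchanging 3,4-dichlorophenyl for 4-(trifluoromethyl)phenyl stays within the scatter, so this pair does not separate the two aryl groups. No measured evidence bears on this result.

Open, from the compounds shown here alone, is whether a carboxylic acid or an amine on the aryl ring would give a step beyond the scatter. Chain length alone also stays open: the step between compound 2 and compound 3 changes it together with the aryl group.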